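The source may hold more compounds than are shown below. What is called first, only, known or untested is meant among the compounds shown, and "the series" means these compounds.

In a functional assay on A-431 cells (Homo sapiens) for inhibition, with a stated time of 72 h (on this read-out lower numbers stand for stronger inhibition and higher numbers for weaker inhibition), compound 1 `Oc1c(CN2CCCC2)ccc2cccnc12` gives 16600 nM, compound 2 `Oc1c(CN2CCCC2)cc(Cl)c2cccnc12` gives 7410 nM and compound 3 `CCOCc1cc(CN2CCCC2)c(O)c2ncccc12` gives 33100 nM. Compound 3 therefore sits level with compound 1 and on the weaker side of compound 2: the data show a 2.0-fold higher number from compound 1 to compound 3 (0.30 log units; within the scatter) and a 4.5-fold higher number from compound 2 to compound 3 (0.65 log units; beyond the scatter). Compound 4 `CCOCc1cc(CN2CCCCC2)c(O)c2ncccc12` carries piperidin-1-yl in place of pyrrolidin-1-yl on a saturated chain carbon bound to an aromatic carbon. Among the measured compounds shown here, no measured step touches this group. The nearest evidence is indirect, since a 2.2-fold lower number from compound 1 to compound 2 (0.35 log units; beyond the scatter) and the two steps above all concern substituents on an aromatic carbon and stay modest or smaller. The expected change is therefore none beyond the scatter in this assay, and the expected step is a 1.3-fold lower number from compound 3 to compound 4 (0.10 log units; within the scatter). Compound 4 is estimated at 26000 nM, within a range of 11000 nM to 60000 nM.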

Compound 4, half-maximal inhibitory concentration: 23400 nM
The estimate for compound 4 lay 1.1-fold (0.05 log units) above the measured number; measured number inside the range.
By their numbers in this assay, from the lowest: compound 2; then compounds 1, 4 and 3 (each within the scatter of the next).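

This is the first change shown at the group on the saturated chain carbon bound to an aromatic carbon, and in this assay it gives a 1.4-fold lower number from compound 3 to compound 4 (0.15 log units; within the scatter). With the ethoxymethyl group in place, going from (pyrrolidin-1-yl)methyl to (piperidin-1-yl)methyl therefore does not separate the two compounds on this read-out. Nothing available explains this result. From the compounds shown here alone, it remains open whether the same exchange would behave alike on compound 1 or compound 2, which lack ethoxymethyl. Also open, going by these compounds, is whether morpholin-4-yl or an open-chain dimethylamino group at this place would move the number beyond the scatter.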